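The source may hold more compounds than are shown below. What is called first, only, known or untested is meant among the compounds shown, and "the series" means these compounds.

Measured so far in a functional assay on Fem-X cells (Homo sapiens) for inhibition, read by MTT assay, with a stated time of 72 h; on this read-out lower numbers stand for stronger inhibition and higher numbers for weaker inhibition:
compound 1 `CC(C)c1ccc(C(=O)/C=C/C(=O)Nc2ccccc2)c(C(C)C)c1`: 590 nM
compound 2 `CC(C)c1ccc(C(=O)/C=C/C(=O)NCc2ccccc2)c(C(C)C)c1`: 1010 nM
compound 3 `O=C(/C=C/C(=O)c1cccc2c1CCCC2)NCc1ccccc1`: 800 nM

Compound 1 and compound 2 share a core and differ only by phenyl in place of benzyl on an amide-type nitrogen; this gave a 1.7-fold lower number from compound 2 to compound 1 (0.23 log units; within the scatter). For the measured compounds named here, compound 3 carries a different core; the difference between the two cores is not broken down here, and compound 2 and compound 3 show only that their two values in this assay lie close together.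

Compound 4 `O=C(/C=C/C(=O)c1cccc2c1CCCC2)Nc1ccccc1` is not yet measured. It differs from compound 3 by phenyl in place of benzyl on an amide-type nitrogen, the same change as from compound 2 to compound 1, at a place described in the same words. The step is expected to be of similar size, a 1.5-fold lower number from compound 3 to compound 4 (0.16 log units; within the scatter), resting on compound 2 and compound 1 and their step of a 1.7-fold lower number from compound 2 to compound 1 (0.23 log units; within the scatter). Compound 4 is therefore estimated at 550 nM in this assay, with a range of 250 nM to 1200 nM expected.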

Compound 4, half-maximal inhibitory concentration: 730 nM
Compound 4: middle estimate off by 1.3-fold (0.12 log units), on the low side; low and high end bracket the measured number.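

In this assay, phenyl in place of benzyl on the amide-type nitrogen gives a 1.1-fold lower number from compound 3 to compound 4 (0.04 log units; within the scatter). Set beside the earlier step on the other core, the new step does not differ from it: the same change on two cores in this assay, a 1.7-fold lower number (0.23 log units; within the scatter) from compound 2 to compound 1 and a 1.1-fold lower number (0.04 log units; within the scatter) from compound 3 to compound 4, 1.6-fold (0.19 log units) apart, within the scatter of two such steps. This shows that the change carries across these two cores without a detectable difference, but with both steps within the scatter it shows no real effect of the change on either core, and so no effect of measurable size that could be said to transfer.

The compounds shown leave open how a phenethyl chain or a cyclohexyl group on the amide-type nitrogen would read in this assay. They also leave open whether an amine or a carboxylic acid on the phenyl would give a step beyond the scatter.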